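Biaryl variation on the piperazine benzyl group

The source may report more compounds than this note shows. Statements on the series, on what has been measured and on what is new or still open speak of the compounds shown alone.

In an assay on isolated protein for displacement of a labelled ligand from Apoptosis regulator Bcl-2 (Homo sapiens), read by fluorescence polarization (a lower number here means a stronger inhibitor, a higher number a weaker inhibitor), compound 1 `CN(C)CC[C@H](CSc1ccccc1)Nc1ccc(S(=O)(=O)NC(=O)c2ccc(N3CCN(Cc4ccccc4S(C)(=O)=O)CC3)cc2)cc1[N+](=O)[O-]` gives 4.6 nM. Among the compounds with values here, compound 2 `CN(C)CC[C@H](CSc1ccccc1)Nc1ccc(S(=O)(=O)NC(=O)c2ccc(N3CCN(Cc4ccccc4-c4cccnc4)CC3)cc2)cc1[N+](=O)[O-]` gives 1 nM in this assay, the lowest of the two numbers measured so far; the step of a 4.6-fold lower number from compound 1 to compound 2 (0.66 log units; beyond the scatter) separates the two compounds and lies beyond the scatter.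

Compound 3 `CN(C)CC[C@H](CSc1ccccc1)Nc1ccc(S(=O)(=O)NC(=O)c2ccc(N3CCN(Cc4ccccc4-c4ccc(S(C)(=O)=O)cc4)CC3)cc2)cc1[N+](=O)[O-]` is the next member. Relative to compound 2 the change is 4-(methylsulfonyl)phenyl in place of pyridin-3-yl on an aromatic carbon. Within the data shown here, the only measured step that bears on it is the one from compound 1 to compound 2, where the methylsulfonyl gave way to the pyridin-3-yl and the number fell by a 4.6-fold lower number from compound 1 to compound 2 (0.66 log units; beyond the scatter). Compound 3 keeps a six-membered aromatic ring at the same place as compound 2 but carries a methylsulfonyl on that ring rather than a ring nitrogen, so it sits between the two measured cases structurally. The number for compound 3 is therefore expected to stay close to that of compound 2, with the step of a 1.8-fold higher number from compound 2 to compound 3 (0.26 log units; within the scatter) expected to lie within or just beyond the scatter, toward a slightly higher number. The estimate for compound 3 in this assay is 1.8 nM, with a range from 0.6 nM to 6 nM.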

Compound 3, inhibition constant: < 1 nM
Compound 3 ended at the assay's limit; the forecaster's own chance of this, stated with the estimate: 2%; middle value at least 1.8-fold (0.25 log units) from the limit.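

Compound 3 reads as a limit of the assay, not as a number: the limit of < 1 nM in this assay, at which 1 of the 3 values shown sits. Even so, the comparison with the methylsulfonyl compound can be read, and it gives an at least 4.6-fold lower number from compound 1 to compound 3 (0.66 log units; beyond the scatter), so the methylsulfonyl group is compatible with a low number at this place when it is carried on a phenyl ring rather than sitting directly on the aromatic carbon. Two different aryl groups, pyridin-3-yl and 4-(methylsulfonyl)phenyl, now both stand beyond the scatter from compound 1 on the low side, on an aromatic carbon ortho to a large group, but the data give only a number no higher from compound 2 to compound 3 (the limit leaves the size open), and the two aryl groups cannot be ranked.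

Open, as far as these compounds go, is whether the methylsulfonyl on the outer ring matters at all, a question that an unsubstituted phenyl at this place would address. Also open, from the compounds shown here alone, is how far the substituent on that ring can vary, for instance a carboxylic acid or an amine in its stead, and any such comparison would meet the same limit if the numbers fall as low as compound 3.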